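This account rests on a few compounds, and the source may have more. Where it says the series, first, only, none or still open, it means among the compounds named here.

Measured compounds in an ADME assay on LLC-MK2 cells (Macaca mulatta) for cytotoxicity, read by spectrophotometry and crystal violet staining, with a stated time of 4 days; on this read-out lower numbers stand for higher toxicity in this test and higher numbers for lower toxicity in this test:

Compound 1 `CC(C)n1ncc2c(C(=O)Nc3ccccc3F)cc(-c3cccnc3)nc21`: 50000 nM
Compound 2 `CC(C)n1ncc2c(C(=O)Nc3c(F)cc(F)cc3F)cc(-c3cccs3)nc21`: a limit, > 200000 nM
Compound 3 `CC(C)n1ncc2c(C(=O)Nc3ccccn3)cc(-c3ccccc3)nc21`: 12500 nM

Compound 2 gives no number in this assay, only a limit, (the limit of > 200000 nM in this assay, at which 1 of the 3 values shown sits). The two compounds with a number both share the core of compound 2 but carry different groups: compound 1 gives 50000 nM and compound 3 gives 12500 nM, so compound 2 stands at the least toxic end of what has been seen so far.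

Compound 4 `CC(C)n1ncc2c(C(=O)Nc3ccc(F)c(F)c3)cc(-c3cccs3)nc21` differs from compound 2 in one place: 3,4-difluorophenyl in place of 2,4,6-trifluorophenyl on an amide-type nitrogen. Going by the values given here, no pair of measured compounds differs in a single place, so the size of such a step is not known from the data. Because compound 2 sits at the limit of > 200000 nM in this assay, at which 1 of the 3 values shown sits, the step is expected to be small, either within the scatter or a modest move toward greater toxicity, giving an expected at least 1.3-fold lower number from compound 2 to compound 4 (0.12 log units; that floor lies within the scatter). Compound 4 is therefore estimated at 150000 nM, in the range 50000 nM to 400000 nM, with a fair chance that this assay again reports only a limit.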

Compound 4, half-maximal cytotoxic concentration: > 200000 nM
Compound 4: no number, only a limit; the forecaster's own chance of this, stated with the estimate: 45%; middle value at least 1.3-fold (0.12 log units) away from the limit.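

In this assay, going by these compounds alone, compound 2 and compound 4 each give only a limit, so putting 3,4-difluorophenyl in place of 2,4,6-trifluorophenyl yields no step that can be read: the limit of > 200000 nM in this assay, at which 2 of the 4 values shown sit. The compounds shown leave open how far any single change moves toxicity in this assay.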